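The source may report more compounds than this note shows. Statements on the series, on what has been measured and on what is new or still open speak of the compounds shown alone.

Compound 1 `O=C(NO)c1ccc(NCc2nc(-c3ccc(Cl)cc3)nn2-c2ccccc2)cc1` — in an assay on Sf9 cells for inhibition of protein deacetylase HDAC6 (Homo sapiens), read by fluorescence, with a stated time of 40 min, tested at 100 nM (on this read-out lower numbers stand for less inhibition and higher numbers for more inhibition at the one concentration tested (going by the name of the read-out)), compound 1 gives 67.2%.
Compound 2 `O=C(NO)c1ccc(NCc2nc(-c3ccsc3)nn2-c2ccccc2)cc1` — in this assay compound 2 gives 53.4%.

Among the compounds with values here, of the two compounds measured, compound 2 stands lowest in this assay; its nearest neighbour is compound 1, and the one measured step runs a number 13.8 percentage points lower from compound 1 to compound 2 (beyond the scatter), a modest drop that lies beyond the scatter.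

Compound 3 `Cc1ccsc1-c1nc(CNc2ccc(C(=O)NO)cc2)n(-c2ccccc2)n1` has not yet been measured in this assay. It differs from compound 2 in one place:

3-methylthiophen-2-yl in place of thiophen-3-yl on an aromatic carbon

Within the data shown here, no measured step bears directly on this change. Among the measured compounds shown here, the only step on record, a number 13.8 percentage points lower from compound 1 to compound 2 (beyond the scatter), concerns a different exchange of the aromatic group on that carbon and so offers no guide to the move from thiophen-3-yl to 3-methylthiophen-2-yl. With nothing to point either way, the expectation for compound 3 in this assay is a step of a number 1.4 percentage points lower from compound 2 to compound 3 (within the scatter), not beyond the scatter. The estimate for compound 3 in this assay is therefore 52%, with a range from 32% to 70%.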

Compound 3, a percentage reported as inhibition, at one concentration (the size of the read-out at that concentration, not a potency): 72.1%
Beside the measured number, compound 3's estimate is 20.1 percentage points below it; the whole stated range lies below it.
By their numbers in this assay, from the lowest: compound 2; then compounds 1 and 3 (each within the scatter of the next).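

In this assay, the exchange of thiophen-3-yl for 3-methylthiophen-2-y on the aromatic carbon between two ring nitrogen atoms gives a number 18.7 percentage points higher from compound 2 to compound 3 (beyond the scatter), which shows that this position can also respond upward and that the thiophene compounds here do not all sit low. The other new comparison gives a number 4.9 percentage points higher from compound 1 to compound 3 (within the scatter), so a five-membered sulfur ring with a methyl group on it holds this read-out level with the 4-chlorophenyl group, and the drop seen with thiophen-3-yl cannot be read as belonging to thiophene rings in general. Nothing available explains why the two thiophene groups part in this way.

The change moves the point of attachment on the thiophene and adds the methyl group together, so the compounds shown leave open how much each contributes; plain thiophen-2-yl and 4-methylthiophen-3-yl would be the groups that separate the two. They also leave open how this position would take a pyridine ring, or a chain ending in an amine or a carboxylic acid, in place of these aromatic groups.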